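The compounds below may be only part of what the source reports. "The series", "measured", "known", "first", "only" and "open" are said of these compounds alone.

Compound 1 (`O=S(=O)(NCCNC(=S)Nc1cc(C(F)(F)F)cc(C(F)(F)F)c1)c1ccc(-c2ccccc2OCc2cccc(O)c2)s1`) records > 50000 nM in a functional assay on HL-60 cells (Homo sapiens) for inhibition, read by CCK-8 assay, with a stated time of 48 h (a lower number here means a stronger inhibitor, a higher number a weaker inhibitor), which is a limit of the assay and not a number. Among the measured compounds shown here, compound 2 (`COc1ccc(NC(=S)NCCNS(=O)(=O)c2sccc2-c2ccc(C)cc2Oc2ccc(O)c(O)c2)cc1`), the only other compound measured, gives 4100 nM in this assay, so a numerical reading is at least possible within this small set. Compound 3 (`O=[N+]([O-])c1ccc(Oc2ccccc2-c2ccc(S(=O)(=O)NCCNC(=S)Nc3cc(C(F)(F)F)cc(C(F)(F)F)c3)s2)cc1`) differs from compound 1 in one place, with 4-nitrophenyl in place of 3-hydroxybenzyl on an oxygen on an aromatic ring. For the measured compounds named here, no measured step bears on this change, so the expectation is loose. It leans only on compound 2 at 4100 nM. A real chance remains that compound 3 also ends at the limit. The expected change in this assay is toward a stronger inhibitor, an estimated step of an at least 4.1-fold lower number from compound 1 to compound 3 (0.61 log units; beyond the scatter). For compound 3 the estimate is 12000 nM, with an expected range of 3000 nM to 45000 nM.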

Compound 3, half-maximal inhibitory concentration: 7200 nM
Compound 3: middle estimate off by 1.7-fold (0.22 log units), on the high side, within the range that was stated.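

On the oxygen on an aromatic ring, 4-nitrophenyl in place of 3-hydroxybenzyl brings the core of compound 1 to a numerical reading in this assay, which the earlier compounds had not shown for this core. The change is an at least 6.9-fold lower number from compound 1 to compound 3 (0.84 log units; beyond the scatter), so this position can affect the reading in this assay. Compound 1 stands at a limit of the assay, so this step gives only a minimum size: the limit of > 50000 nM in this assay, at which 1 of the 3 values shown sits.

The change replaces the whole group, so the compounds shown do not separate the part played by the nitro group, the lost hydroxyl and the different attachment to the oxygen. From the compounds shown here alone, whether a 4-aminophenyl or a 4-carboxyphenyl group on the same oxygen would keep, extend or lose this reading remains open.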